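The compounds below may be only part of what the source reports. "The series", "measured", "known", "first", "only" and "open" are said of these compounds alone.

Measured so far:
- compound 1, `CN(C)c1cccc(-c2nc3cccnc3n2C2CCCC2)c1`: 455 nM
- compound 2, `O=C(O)c1ccc(-c2nc3cccnc3n2C2CCCC2)cc1`: 600 nM
- compound 3, `COc1ncc(-c2nc3cccnc3n2C2CCCC2)c(OC)n1`: limit, > 10000 nM

Of the compounds shown here, three sharing one core have been tested in a functional assay on MDA-MB-231 cells (Homo sapiens) for cytotoxicity, read by MTT assay, with a stated time of 24 h; a higher number here means a weaker inhibitor, a lower number a stronger inhibitor. Compound 2 gives 600 nM in this assay, the higher of the two numbers that were read as values. Its nearest neighbour is compound 1, which gives 455 nM in this assay, a gap that stays within the scatter, so the two cannot be ranked against each other. Compound 3 reached only (the limit of > 10000 nM in this assay, at which 1 of the 3 values shown sits), and the value is a limit rather than a number.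

Among the compounds with values here, no single-point step between measured compounds is available, so the step now considered has no measured precedent. Compound 4, `c1cncc(-c2ccc(-c3nc4cccnc4n3C3CCCC3)cc2)c1`, differs from compound 2 as follows: pyridin-3-yl in place of carboxy on an aromatic carbon. The aromatic ring that enters is bound directly where the carboxy left, para to a large group.

Within the data shown here, with no measured step to lean on, the account expects a step in this assay that is small, possibly a modest move toward a lower number, and quite possibly none beyond the scatter. For compound 4 the expected value in this assay is 400 nM, within a range from 100 nM to 2000 nM, which corresponds to an expected step of a 1.5-fold lower number from compound 2 to compound 4 (0.18 log units; within the scatter).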

Compound 4, half-maximal inhibitory concentration: > 10000 nM
Compound 4 was reported as a limit; the forecaster's own chance of this, stated with the estimate: 10%; at least 25-fold (1.39 log units) between middle value and limit.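

In this assay, within the data shown here, the first step that can be read at this place, on an aromatic carbon para to a large group, is far from neutral: pyridin-3-yl in place of carboxy gives an at least 16-fold higher number from compound 2 to compound 4 (1.22 log units; beyond the scatter). Among these compounds, the earlier compounds offered no such step, so this is the first sign that the group held at this place can decide the read-out on the shared core, and that an aromatic ring bound directly here does not carry over the number of compound 2. The value of compound 4 is a limit and not a number, and it is not alone there: the limit of > 10000 nM in this assay, at which 2 of the 4 values shown sit.

The change does several things at once, since a hydrogen-bond donor leaves, a six-membered aromatic ring enters and the count of heavy atoms rises, and the compounds shown do not separate these. As far as these compounds go, it remains open whether a primary amide or a hydroxymethyl group at this place would stay close to compound 2, and whether a plain phenyl ring would behave as pyridin-3-yl does.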